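Loss of one pyrazole methyl in the acylurea sulfone series

The source may hold more compounds than are shown below. What is called first, only, known or untested is meant among the compounds shown, and "the series" means these compounds.

Measured so far:
compound 1, `CN1CCC(S(=O)(=O)c2ccc3nc(NC(=O)NC(=O)c4cc5c(cc4Cl)CCN5C)sc3c2)CC1`, 2.8
compound 2, `Cc1cc(C)n(-c2ccc(Cl)c(C(=O)NC(=O)Nc3nc4ccc(S(=O)(=O)CCCN5CCN(C)CC5)cc4s3)c2)n1`, 2.5

In a physicochemical assay for lipophilicity (a higher number here means a more lipophilic compound, a lower number a more polar compound), compound 1 gives 2.8. In this assay compound 2 gives 2.5; the gap between compound 2 and compound 1 lies within the scatter, so no order between the two can be set on these numbers.

Compound 3, `Cc1ccn(-c2ccc(Cl)c(C(=O)NC(=O)Nc3nc4ccc(S(=O)(=O)CCCN5CCN(C)CC5)cc4s3)c2)n1`, is not yet measured. It differs from compound 2 in one place: hydrogen in place of methyl on an aromatic carbon. Within the data shown here, no step between measured compounds of this kind is available, so the expectation rests only on the single carbon removed. A small step downward is expected, of the size a number 0.40 log units lower from compound 2 to compound 3 (beyond the scatter), close to the edge of the scatter. Compound 3 is expected to give about 2.1 in this assay, within the range 1.6 to 2.6.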

Compound 3, distribution coefficient: 2.6
The estimate for compound 3 lay 0.50 log units below the measured number; low and high end bracket the measured number.
By their numbers in this assay, from the lowest: compounds 2, 3 and 1 (each within the scatter of the next).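

Among these compounds, the first single-place pair is compound 2 and compound 3, and in this assay the change from 3,5-dimethyl-1H-pyrazol-1-yl to 3-methyl-1H-pyrazol-1-yl gives a number 0.10 log units higher from compound 2 to compound 3 (within the scatter). At this aromatic carbon, next to the ring atom that bears a large group, hydrogen in place of methyl therefore leaves the two compounds without any order on this read-out, and the step holds for this one pair only. No measurement at hand offers an account of this result.

Still open, going by these compounds, is what happens at this same carbon with a group other than hydrogen or methyl, such as an ethyl group, an amine or a carboxylic acid. Among the compounds shown here, also open is what the remaining methyl on the ring contributes, as no pair here isolates that position.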